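Working notes: methylsulfanyl in place of hydrogen, compound 2 to 3

The source may report more compounds than this note shows. Statements on the series, on what has been measured and on what is new or still open speak of the compounds shown alone.

compound 1 `O=C(COc1cccc2ccccc12)N/N=C/c1ccc([N+](=O)[O-])cc1` in an ADME assay on MT4 cells (Homo sapiens) for cytotoxicity, read by MTT assay, with a stated time of 4 days; a lower number here means that less compound is tolerated, a higher number that more compound is tolerated: 87.9 ug/mL
compound 2 `O=C(COc1cccc2ccccc12)N/N=C/c1ccccc1` in this assay: >= 96.6 ug/mL, a limit of the assay

Compound 2 stands at the limit of >= 96.6 ug/mL in this assay, at which 1 of the 2 values shown sits; only a limit is known for it, not a number. Compound 3 `CSc1ccc(/C=N/NC(=O)COc2cccc3ccccc23)cc1` differs from compound 2 by methylsulfanyl in place of hydrogen on an aromatic carbon. Going by the values given here, the one measured step, an at least 1.0-fold higher number from compound 1 to compound 2 (0.04 log units; that floor lies within the scatter), also swaps a group on an aromatic carbon and lies within the scatter. No step beyond the scatter is therefore expected, and the expected step of an at least 1.1-fold lower number from compound 2 to compound 3 (0.05 log units; that floor lies within the scatter) sits near zero. Compound 3 is estimated at 85 ug/mL, with a range from 40 ug/mL to 100 ug/mL.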

Compound 3, half-maximal cytotoxic concentration: 68.3 ug/mL
Compound 3: middle estimate off by 1.2-fold (0.09 log units), on the high side; the range from low to high includes it.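

In this assay, methylsulfanyl on the aromatic carbon para to a large group gives an at least 1.4-fold lower number from compound 2 to compound 3 (0.15 log units; that floor lies within the scatter). That step is only a floor, since compound 2 has a limit of the assay and not a number. Against nitro on the same carbon, methylsulfanyl gives a 1.3-fold lower number from compound 1 to compound 3 (0.11 log units; within the scatter), the first step at this position with a full size, and neither group is separated from the other beyond the scatter.

From the compounds shown here alone, how far compound 2 truly lies from compound 1 and compound 3 stays open. So does whether an amine or a carboxylic acid on this carbon would move the number beyond the scatter.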